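Dichloro Benzimidazole Pyrazoles Tested on HeLa Cells

This account rests on a few compounds, and the source may have more. Where it says the series, first, only, none or still open, it means among the compounds named here.

Measured so far:
Compound 1, `Cc1cc2nc(-c3cn(-c4ccccc4)nc3-c3ccccc3)[nH]c2cc1C`: 41500 nM
Compound 2, `Clc1ccc(-c2nn(-c3ccccc3)cc2-c2nc3cc(Cl)ccc3[nH]2)cc1`: 1630 nM
Compound 3, `Cc1cc2nc(-c3cn(-c4ccccc4)nc3-c3ccc(Cl)cc3)[nH]c2cc1C`: 21800 nM

In a functional assay on HeLa cells (Homo sapiens) for antiproliferative activity, read by MTT assay, with a stated time of 48 h (on this read-out higher numbers stand for weaker inhibition and lower numbers for stronger inhibition), compound 2 gives the lowest of the three numbers; its values against compound 3 and compound 1 both lie beyond the scatter. How the core of compound 2 differs from the core of compound 1 is not broken down here.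

Between compound 1 and compound 3 the change is chloro in place of hydrogen on an aromatic carbon. It gave a 1.9-fold lower number from compound 1 to compound 3 (0.28 log units; within the scatter).

Compound 4, `Clc1ccc(-c2nn(-c3ccccc3)cc2-c2nc3cc(Cl)c(Cl)cc3[nH]2)cc1`, is not yet measured. It differs from compound 2 by chloro in place of hydrogen on an aromatic carbon. This is the same kind of change as from compound 1 to compound 3, but the surroundings differ: in compound 3 the chloro sits para to a large group on a phenyl, whereas in compound 4 it enters a six-membered carbon ring of a fused system, ortho to a chloro group, meta and para to the fused ring.

Resting on the small step seen in a 1.9-fold lower number from compound 1 to compound 3 (0.28 log units; within the scatter), a step of similar size is expected for compound 4, a 1.5-fold lower number from compound 2 to compound 4 (0.17 log units; within the scatter). Compound 4 is therefore estimated at 1100 nM, between 350 nM and 3500 nM.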

Compound 4, half-maximal inhibitory concentration: 12100 nM
Beside the measured number, compound 4's estimate is 11-fold (1.04 log units) below it; the whole stated range lies below it.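

In this assay, chloro in place of hydrogen on an aromatic carbon gave a 7.4-fold higher number from compound 2 to compound 4 (0.87 log units; beyond the scatter), so on this core the change raised the number beyond the scatter, and the two steps differ: the same change on two cores in this assay, a 1.9-fold lower number (0.28 log units; within the scatter) from compound 1 to compound 3 and a 7.4-fold higher number (0.87 log units; beyond the scatter) from compound 2 to compound 4, 14-fold (1.15 log units) apart, beyond the scatter of two such steps. This shows that, among the compounds shown, the result of this change did not carry from the core of compound 1 to the core of compound 2, so the earlier step is a poor guide to the later one. Among these compounds, it does not show why, since there are only two pairs and the chloro enters a different place in each, on a six-membered carbon ring of a fused system, ortho to a chloro group, in compound 4, so the core and the place cannot be told apart.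

On these data alone, whether a methyl group, a methoxy group or an amine on that same aromatic carbon of compound 2 would raise the number as well remains open. So does whether the step from chloro would hold on a core carrying a carboxylic acid or a longer chain.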